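Removing One Chloro From a Poorly Soluble Compound

The compounds below may be only part of what the source reports. "The series", "measured", "known", "first", "only" and "open" are said of these compounds alone.

Compound 1 `CC(=O)Nc1nc(-c2ccc(Cl)c(Cl)c2)cs1`: < 1000 nM (a limit)
Compound 2 `O=C(Nc1nc(-c2ccc(Cl)c(Cl)c2)cs1)C1CC1`: 3000 nM
Compound 3 `CS(=O)(=O)Nc1nc(-c2ccc(Cl)c(Cl)c2)cs1`: 429000 nM

All three compounds were tested in a physicochemical assay for solubility, measured as kinetic solubility, with a stated time of 1 h, at pH 7.4; on this read-out higher numbers stand for higher solubility and lower numbers for lower solubility. Compound 1 has only a limit and no exact number: the limit of < 1000 nM in this assay, at which 1 of the 3 values shown sits. Compound 4 `CC(=O)Nc1nc(-c2cccc(Cl)c2)cs1` has hydrogen in place of chloro on an aromatic carbon.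

Within the data shown here, no measured step changes a chloro group, so the evidence is indirect. Each step changes the group on nitrogen. The first is an at least 3.0-fold higher number from compound 1 to compound 2 (0.47 log units; beyond the scatter). The other two are an at least 420-fold higher number from compound 1 to compound 3 (2.63 log units; beyond the scatter) and a 140-fold higher number from compound 2 to compound 3 (2.16 log units; beyond the scatter). Compound 4 keeps the acetyl of compound 1 and lacks the methylsulfonyl of compound 3 , which gives 429000 nM, so a change of that scale is not expected. The smaller at least 3.0-fold higher number from compound 1 to compound 2 (0.47 log units; beyond the scatter) is the closer guide to size, and a modest rise is expected. The expected step is an at least 2.0-fold higher number from compound 1 to compound 4 (0.30 log units; that floor lies within the scatter). For compound 4 the estimated value is 2000 nM, with an expected range from 600 nM to 10000 nM.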

Compound 4, solubility: 2000 nM
For compound 4 middle estimate and measured number coincide at the digits printed, and the stated range covers the measured number.
By their numbers in this assay, from the lowest: compounds 4 and 2 (each within the scatter of the next); then compound 3. At a limit, below all of these: compound 1.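

Among these compounds, this is the first step at the aromatic ring rather than on the nitrogen: compound 4 carries hydrogen where compound 1 has the chloro that sits para to a group of 9 heavy atoms, and the other chloro stays in place. In this assay this change gives an at least 2.0-fold higher number from compound 1 to compound 4 (0.30 log units; that floor lies within the scatter), so the aromatic ring can be altered here without the number falling out of the measurable range. Compound 1 has a limit rather than an exact number, so the true size of this step cannot be read: the limit of < 1000 nM in this assay, at which 1 of the 4 values shown sits.

The compounds shown leave open what a fluoro, a methoxy or an amine would give at this place, and what replacing the remaining chloro would give. They also leave open how the same swap would act on compound 3, with its methylsulfonyl group.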